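The source may hold more compounds than are shown below. What is called first, only, known or untested is meant among the compounds shown, and "the series" means these compounds.

The series rests on a shared core that compound 1 `O=C(O[C@H]1C[C@H](n2cc(F)c(=O)[nH]c2=O)O[C@@H]1COP(=O)(O)Oc1ccccc1)c1ccccc1` carries with a phenyl on the phosphate oxygen. In a functional assay on Caco-2 cells (Homo sapiens) for cytotoxicity, read by MTT assay, with a stated time of 48 h (a lower number here means a stronger inhibitor, a higher number a weaker inhibitor), compound 1 gives 1020 nM. Compound 2 `O=C(O[C@H]1C[C@H](n2cc(F)c(=O)[nH]c2=O)O[C@@H]1COP(=O)(O)Oc1ccc2ncccc2c1)c1ccccc1` differs only at that oxygen, and in this assay compound 2 gives 2460 nM; the step of a 2.4-fold higher number from compound 1 to compound 2 (0.38 log units; beyond the scatter) is the one measured step among these compounds. Compound 3 `CCCCCCCCCC[n+]1cccc(OP(=O)([O-])OC[C@H]2O[C@@H](n3cc(F)c(=O)[nH]c3=O)C[C@@H]2OC(=O)c2ccccc2)c1` carries a decyl chain on its aromatic nitrogen and in this assay compound 3 gives 12900 nM, the highest of the three numbers, beyond the scatter from both compound 2 and compound 1.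

Compound 4 `CCOC(=O)C[n+]1cccc(OP(=O)([O-])OC[C@H]2O[C@@H](n3cc(F)c(=O)[nH]c3=O)C[C@@H]2OC(=O)c2ccccc2)c1` is made from compound 3 by one change: ethoxycarbonyl in place of nonyl on a saturated chain carbon bound to an aromatic nitrogen. Within the data shown here, no measured step touches this part of the molecule; the only measured step, the change of the aryl group on the phosphate oxygen, was modest and gives no guide to a change on the chain bound to the aromatic nitrogen. Compound 4 is therefore expected to stay near compound 3, with no step beyond the scatter in either direction being firmly predicted, the expected step being a 1.2-fold higher number from compound 3 to compound 4 (0.07 log units; within the scatter). For compound 4 in this assay the estimate is 15000 nM, within a wide range from 5000 nM to 45000 nM.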

Compound 4, half-maximal inhibitory concentration: 2620 nM
Beside the measured number, compound 4's estimate is 5.7-fold (0.76 log units) above it, outside the stated range (below it).
By their numbers in this assay, from the lowest: compound 1; then compounds 2 and 4 (each within the scatter of the next); then compound 3.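

In this assay, the step of a 4.9-fold lower number from compound 3 to compound 4 (0.69 log units; beyond the scatter) shows that the group on a saturated chain carbon bound to an aromatic nitrogen is not a silent site: exchanging nonyl for ethoxycarbonyl moves the number beyond the scatter, and in the direction of a stronger inhibitor. Among these compounds, this is the first measured change at this position, and its size is larger than that of the only earlier step, which concerned the aryl group on the phosphate oxygen. The exchange alters several things at once, replacing an all-carbon chain without hydrogen-bond acceptors with a smaller group that has a double bond outside aromatic rings and hydrogen-bond acceptors, and no measurement here links the shift to any one of these differences.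

The compounds shown leave open whether chain length alone or the ester accounts for the step, a question that a short all-carbon chain such as ethyl or propyl at this place could help to separate. They also leave open how a carboxylic acid or an amide in place of the ethyl ester would read in this assay.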